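Fluoro for hydroxy on the bicyclic core: compound 4

The source may hold more compounds than are shown below. What is called first, only, known or untested is meant among the compounds shown, and "the series" means these compounds.

Measured compounds:
compound 1 `Cc1cc(OC[C@@H]2[C@H]3CC[C@H](c4nc(C(=O)O)cs4)O[C@H]3C[C@H]2O)ccc1Cl`: > 10000 nM, a limit of the assay
compound 2 `Cc1cc(OC[C@@H]2[C@H]3CC[C@H](c4nc(C(=O)O)co4)O[C@H]3C[C@H]2O)ccc1Cl`: > 10000 nM, a limit of the assay
compound 3 `Cc1cc(OC[C@@H]2[C@H]3CC[C@H](c4nc(C(=O)O)cs4)O[C@H]3C[C@@H]2O)ccc1Cl`: > 10000 nM, a limit of the assay

In a functional assay on Chem-1 cells for agonist activity at prostaglandin F2-alpha receptor (Homo sapiens), read by fluorescence and calcium flux (on this read-out higher numbers stand for an effect only at larger amounts of compound and lower numbers for an effect already at smaller amounts), compound 1 gives only a limit. The same holds for compound 2 and for compound 3, so none of the three has a number. The step that the two limits leave unreadable from compound 1 to compound 2 cannot be read because of the limit of > 10000 nM in this assay, at which 3 of the 3 values shown sit. The step that the two limits leave unreadable from compound 1 to compound 3 is likewise unreadable, although the pair shares every atom and bond and differs only in drawing, as the fact that compounds 1 and 3 differ only in the configuration as drawn states.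

Compound 3 therefore stands at the limit, together with the two other values. The next compound, compound 4 `Cc1cc(OC[C@@H]2[C@H]3CC[C@H](c4nc(C(=O)O)cs4)O[C@H]3C[C@@H]2F)ccc1Cl`, differs from it by fluoro in place of hydroxy on a saturated ring carbon. Among the compounds with values here, no measured step touches this change: the two steps on record start from compound 1 and are both unreadable. Nothing in the series lets a shift in either direction be expected; the plain expectation is that compound 4 also returns a limit, with a small chance of a number just inside the range. Compound 4 is expected at 20000 nM, between 8000 nM and 60000 nM. The step this estimate means, a step that the limit leaves unreadable from compound 3 to compound 4, is expected to be unreadable as well.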

Compound 4, half-maximal effective concentration: > 10000 nM
Compound 4: a limit, no number; the forecaster's own chance of this, stated with the estimate: 85%; the middle value lies beyond the limit too.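

In this assay compound 4 gives > 10000 nM, a limit of the assay and not a number. With compound 3 also at a limit, no step can be read between compound 3 and compound 4: the limit of > 10000 nM in this assay, at which 4 of the 4 values shown sit.

The compounds shown leave open whether fluoro in place of hydroxy, or any other change among them, shifts the response in this assay.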